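Cyano for Dimethylcarbamoyl: Estimating a Diaminotriazine Urea

The compounds below may be only part of what the source reports. "The series", "measured", "known", "first", "only" and "open" are said of these compounds alone.

Compound 1 `CN(C)C(=O)c1cccc(NC(=O)NCc2cccc(N3C(N)=NC(N)=NC3(C)C)c2)c1`: 7.77
Compound 2 `CC1(C)N=C(N)N=C(N)N1c1ccc(OCC(=O)Nc2ccc(S(=O)(=O)F)cc2)c(Cl)c1`: 7.43
Compound 3 `CC1(C)N=C(N)N=C(N)N1c1ccc(CCc2ccc(S(=O)(=O)F)c(Cl)c2)c(Cl)c1`: 7.85

Of the compounds shown here, three have been measured in an assay on isolated protein for inhibition of Dihydrofolate reductase (Mus musculus); on this read-out lower numbers stand for lower potency and higher numbers for higher potency (the scale is a negative logarithm). Among them compound 1 stands second highest of the three numbers. Its nearest neighbour is compound 3, whose value lies slightly higher, a gap that falls within the usual scatter of this assay, so the two cannot be ordered. Compound 2 lies lower by a gap that is beyond the scatter.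

Compound 4 `CC1(C)N=C(N)N=C(N)N1c1cccc(CNC(=O)Nc2cccc(C#N)c2)c1` has not yet been measured in this assay. It differs from compound 1 in one place: cyano in place of dimethylcarbamoyl on an aromatic carbon. The group that leaves has more heavy atoms than the group that enters, while the count of hydrogen-bond donors and acceptors stays the same. Going by the values given here, no measured pair among the three compounds shows this same exchange, so nothing in the data fixes the size of the step.

Without such a reference, a step of modest size is expected, more likely downward than upward, but not necessarily beyond the scatter. The estimate for compound 4 in this assay is 7.5, with a range from 6.9 to 8.1. This corresponds to an expected step of a number 0.27 log units lower from compound 1 to compound 4 (within the scatter).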

Compound 4, logarithm of the reciprocal of the active concentration, log(1/C): 8.19
Compound 4: middle estimate off by 0.69 log units, on the low side; measured number outside the range, above it.
By their numbers in this assay, from the lowest: compound 2; then compounds 1 and 3 (each within the scatter of the next); then compound 4.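

In this assay, going by these compounds alone, the exchange of dimethylcarbamoyl for cyano on an aromatic carbon, meta to a large group, gives the first direct reading at this position: a number 0.42 log units higher from compound 1 to compound 4 (beyond the scatter). The group that enters has fewer heavy atoms than the group that leaves, and the counts of hydrogen-bond donors and acceptors stay the same, so the full dimethylcarbamoyl group is not needed to reach the level of compound 1 at 7.77, and the shorter cyano group does better here. The compounds shown offer no measurement that accounts for this gain, so the step stands as an observation without an explanation.

Going by these compounds, what remains open is whether the gain belongs to cyano itself or would come with any small group at this place; a single exchange cannot separate the two, and a primary amide, a methoxy group or a plain hydrogen on the same aromatic carbon would be the comparisons to read. On these data alone, whether the same exchange gives a step of similar size on another member of the series also stays unknown.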